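The source may hold more compounds than are shown below. What is called first, only, known or untested is meant among the compounds shown, and "the series" means these compounds.

Measured so far in a functional assay on aorta for antagonist activity at Alpha-1D adrenergic receptor (Rattus norvegicus); a higher number here means weaker binding, a lower number tighter binding:
compound 1 `Cc1ccccc1N1CCN(CCCNc2ncccc2C(=O)N(C)C)CC1` — 10 nM
compound 2 `CSc1ccccc1N1CCN(CCCNc2ncccc2C(=O)N(C)C)CC1` — 31.6 nM
compound 3 `CN(C)C(=O)c1cccnc1NCCCN1CCN(c2ccccc2C2CC2)CC1` — 63.1 nM

Compound 3 gives the highest number of the three in this assay; its step from compound 2 is within the scatter, a 2.0-fold higher number from compound 2 to compound 3 (0.30 log units; within the scatter), while its step from compound 1 is beyond it, a 6.3-fold higher number from compound 1 to compound 3 (0.80 log units; beyond the scatter). Compound 4 `COc1cc(C)ccc1N1CCN(CCCNc2ncccc2C(=O)N(C)C)CC1` is not yet measured. It differs from compound 3 in one place: 2-methoxy-4-methylphenyl in place of 2-cyclopropylphenyl on an amine nitrogen in a ring.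

Of the measured steps, the one that bears most directly on this change is the one that removes the cyclopropyl, a 6.3-fold higher number from compound 1 to compound 3 (0.80 log units; beyond the scatter), since compound 4 again carries a methyl on its aromatic ring; the methylsulfanyl step, a 3.2-fold higher number from compound 1 to compound 2 (0.50 log units; beyond the scatter), shows that other groups at that place also sit above compound 1. Going by the values given here, no measured compound carries a methoxy, so the methoxy part of the change has no measured step behind it. Compound 4 is therefore expected to give a lower number than compound 3 in this assay, a step of about a 3.2-fold lower number from compound 3 to compound 4 (0.50 log units; beyond the scatter). For compound 4 the estimate is 20 nM, with a range from 6 nM to 70 nM.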

Compound 4, dissociation constant: 39.8 nM
The estimate for compound 4 lay 2.0-fold (0.30 log units) below the measured number, and the stated range covers the measured number.
By their numbers in this assay, from the lowest: compound 1; then compounds 2, 4 and 3 (each within the scatter of the next).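

In this assay, 2-methoxy-4-methylphenyl on the amine nitrogen in a ring cannot be told apart from 2-cyclopropylphenyl, a 1.6-fold lower number from compound 3 to compound 4 (0.20 log units; within the scatter), or from 2-(methylsulfanyl)phenyl, a 1.3-fold higher number from compound 2 to compound 4 (0.10 log units; within the scatter). Against 2-methylphenyl the same group stays beyond the scatter, a 4.0-fold higher number from compound 1 to compound 4 (0.60 log units; beyond the scatter), so a methyl on the aromatic ring, when it comes with a methoxy, does not bring the number back to that of compound 1, which now stands apart from all three other compounds. No evidence on hand accounts for this result.

On these data alone, the methoxy and the methyl of compound 4 enter together, so what each contributes alone remains open. Also open, as far as these compounds go, is how a chlorine or a hydroxyl at the place of the methyl of compound 1 would read in this assay.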